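The source may hold more compounds than are shown below. What is called first, only, known or untested is meant among the compounds shown, and "the series" means these compounds.

Compound 1 `COc1cc(-c2cc(/C=C/C(=O)c3ccc(N)cc3)[nH]n2)cc(OC)c1OC` gives -83%; compound 2 `COc1ccc(-c2cc(/C=C/C(=O)c3ccc(OC)c(OC)c3)[nH]n2)cc1` gives -100%.

Both values come from a functional assay on SK-MEL-28 cells (Homo sapiens) for cytotoxicity, read by sulforhodamine B assay, with a stated time of 48 h, tested at 100 uM; a higher number here means a weaker effect of the compound at the concentration tested, a lower number a stronger effect. On these two numbers compound 1 stands highest; its nearest neighbour, compound 2, lies lower by a gap beyond the usual scatter, so the two values show compound 2 with the stronger effect at the tested concentration. Among the compounds with values here, no single-point step between the measured compounds is at hand. Compound 3 `COc1cc(-c2cc(/C=C/C(=O)c3ccc(Cl)c(Cl)c3)[nH]n2)cc(OC)c1OC` has not yet been measured in this assay. It differs from compound 1 in one place: 3,4-dichlorophenyl in place of 4-aminophenyl on a carbonyl carbon. Both measured compounds already give strongly negative readings, and nothing among them ties the 4-aminophenyl group to the size of the reading. Compound 3 is therefore expected to give a value close to that of compound 1, with a slight downward lean. The step is expected to be a number 7 percentage points lower from compound 1 to compound 3 (within the scatter), not beyond the scatter. The estimate for compound 3 is -90%, between -100% and -60%.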

Compound 3, a percentage reported as activity, at one concentration (the size of the read-out at that concentration, not a potency): -16%
The estimate for compound 3 lay 74 percentage points below the measured number; measured number above the stated range.
By their numbers in this assay, from the lowest: compound 2; then compound 1; then compound 3.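

In this assay, 3,4-dichlorophenyl in place of 4-aminophenyl on a carbonyl carbon gives a number 67 percentage points higher from compound 1 to compound 3 (beyond the scatter), so with the rest of the molecule unchanged, this single change greatly weakens the effect at the tested concentration. The group at this position therefore has a large bearing on the reading, which the two earlier compounds, differing in more than one place, could not show. Nothing at hand accounts for the size of this step.

The change removes the amine and adds two chlorines in one move, so the compounds shown leave open which of these matters more. On these data alone, how an unsubstituted phenyl or a 4-hydroxyphenyl on the same carbonyl carbon would read also remains open.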